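The compounds below may be only part of what the source reports. "The series", "measured", "known", "first", "only" and "open" are said of these compounds alone.

Of the compounds shown here, three built on a shared core have been tested in a functional assay on C6 cells (Rattus norvegicus) for cytotoxicity, read by MTT assay, with a stated time of 24 h, tested at 6 ug/mL; a higher number here means a weaker effect of the compound at the concentration tested, a lower number a stronger effect. Compound 2 `Cc1ccc(-c2cs/c(=N/NC(=O)CSc3nncn3C)n2-c2ccccc2)cc1` gives 74.6%. Compound 1 `Cc1ccc(-c2cs/c(=N/NC(=O)CSc3nnnn3-c3ccccc3)n2-c2ccccc2)cc1` carries, relative to compound 2, (1-phenyl-1H-tetrazol-5-yl in place of 4-methyl-4H-1,2,4-triazol-3-yl on a sulfur). In this assay compound 1 gives 66.8%. The step between these two, a number 7.8 percentage points lower from compound 2 to compound 1 (within the scatter), is too small to be told apart from the usual scatter of repeated measurements. Compound 3 `Cn1cnnc1SCC(=O)N/N=c1/scc(-c2ccccc2)n1-c1ccccc1` gives 90%, the highest of the three numbers, and its steps to both other compounds lie beyond the scatter.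

Compound 4 `O=C(CSc1nnnn1-c1ccccc1)N/N=c1/scc(-c2ccccc2)n1-c1ccccc1` has not yet been measured. Its core is that of compound 3, which differs from the core of compound 2 by hydrogen in place of methyl on an aromatic carbon, a change measured as the step of a number 15.4 percentage points higher from compound 2 to compound 3 (beyond the scatter). On that core, compound 4 carries 1-phenyl-1H-tetrazol-5-yl in place of 4-methyl-4H-1,2,4-triazol-3-yl on a sulfur. Among the measured compounds shown here, this is the same change as the one from compound 2 to compound 1: in both pairs the exchanged group sits on a sulfur whose other neighbours are a saturated chain carbon, described in identical words. Because the earlier step of a number 7.8 percentage points lower from compound 2 to compound 1 (within the scatter) stayed within the scatter, compound 4 is expected to land close to compound 3, with an estimated step of a number 8 percentage points lower from compound 3 to compound 4 (within the scatter). In this assay compound 4 is therefore estimated at 82%, most likely falling between 68% and 96%, an expectation resting on a single earlier pair and thus held loosely.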

Compound 4, a percentage reported as activity, at one concentration (the size of the read-out at that concentration, not a potency): 52.1%
Compound 4: the middle estimate sits 29.9 percentage points above what was measured; measured number below the stated range.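

In this assay, the exchange of 4-methyl-4H-1,2,4-triazol-3-yl for 1-phenyl-1H-tetrazol-5-yl on a sulfur did not carry over from one core to the other, for it gives a number 37.9 percentage points lower from compound 3 to compound 4 (beyond the scatter), and the two pairs clearly disagree: the same change on two cores in this assay, a number 7.8 percentage points lower (within the scatter) from compound 2 to compound 1 and a number 37.9 percentage points lower (beyond the scatter) from compound 3 to compound 4, 30.1 percentage points apart, beyond the scatter of two such steps

The same four compounds can be read the other way round, and hydrogen in place of methyl on an aromatic carbon, which raised the number on the triazole side, now gives a number 14.7 percentage points lower from compound 1 to compound 4 (beyond the scatter), so its direction is reversed: the same change on two cores in this assay, a number 15.4 percentage points higher (beyond the scatter) from compound 2 to compound 3 and a number 14.7 percentage points lower (beyond the scatter) from compound 1 to compound 4, 30.1 percentage points apart, beyond the scatter of two such steps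

The two changes therefore do not simply add up among these four compounds, and the outcome of each depends on the other, but with one pair per core this shows neither why that happens nor whether it holds for any other exchange in the series.

Going by these compounds, it remains open whether a chlorine or a methoxy group in place of the methyl on the aromatic carbon would also alter the outcome of the exchange on the sulfur. On these data alone, it is equally open how a simpler group on that sulfur, such as a short chain ending in an amine or a carboxylic acid, would behave on either core.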